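Swapping a Sulfur Tether for an Oxygen One

The compounds below may be only part of what the source reports. "The series", "measured", "known", "first", "only" and "open" are said of these compounds alone.

Compound 1, `CC(C)CSc1nc(N)nc2c1ncn2/C=C1/CC1(CO)CO`, is one of three close relatives tested for how much of each a cell line tolerates. In an ADME assay on Akata cells (Homo sapiens) for cytotoxicity, with a stated time of 7 days (a higher number here means that more compound is tolerated, a lower number that less compound is tolerated), compound 1 gives > 20000 nM, which is a limit of the assay rather than a number. Compound 2, `Nc1nc(NCc2ccccc2)c2ncn(/C=C3/CC3(CO)CO)c2n1`, differs from compound 1 by a benzylamino in place of isobutylsulfanyl on an aromatic carbon. In this assay compound 2 gives > 24000 nM, again a limit. Compound 3, `CCCCCCSc1nc(N)nc2c1ncn2/C=C1/CC1(CO)CO`, carries a pentyl in place of isopropyl on a saturated chain carbon bound to a sulfur. In this assay compound 3 gives > 20000 nM, also a limit. The steps a step that the two limits leave unreadable from compound 1 to compound 2, a step that the two limits leave unreadable from compound 1 to compound 3 and a step that the two limits leave unreadable from compound 2 to compound 3 therefore cannot be sized. Compound 4, `CCCCOc1nc(N)nc2c1ncn2/C=C1/CC1(CO)CO`, differs from compound 1 in one place: butoxy in place of isobutylsulfanyl on an aromatic carbon. Going by the values given here, no measured step reads on this change, and the three limits give no direction, so nothing beyond the scatter is expected in this assay. Compound 4 is expected to give 20000 nM, between 10000 nM and 40000 nM. The expected step is a number no higher from compound 1 to compound 4 (the limit leaves the size open), with the result most likely reported once more as a limit.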

Compound 4, half-maximal cytotoxic concentration: > 20000 nM
Compound 4: no number, only a limit; the forecaster's own chance of this, stated with the estimate: 85%; the middle value sits exactly at the limit.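

In this assay, going by these compounds alone, compound 4 gives > 20000 nM, a limit and not a number, so no step between it and compound 1, compound 2 or compound 3 can be read. The compounds shown leave open how much of each the cells tolerate, and whether butoxy in place of isobutylsulfanyl changes that at all.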